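The compounds below may be only part of what the source reports. "The series", "measured", "known", "first", "only" and "open" are said of these compounds alone.

Compound 3 `Cc1ccc(N2C(=O)C/C(=C\c3cccc(C(=O)Nc4ccc(Cl)cc4)c3)C2=O)cc1` stands at the edge of what the assay can report. In an ADME assay on SW480 cells (Homo sapiens) for cytotoxicity, read by MTT assay, with a stated time of 72 h (a lower number here means a stronger inhibitor, a higher number a weaker inhibitor), compound 3 gives > 100000 nM, which is a limit of the assay and not a number. Compound 1 `Cc1ccc(N2C(=O)C/C(=C\c3cccc(C(=O)Nc4cccc(F)c4)c3)C2=O)cc1` in this assay gives 96900 nM. Compound 2 `COc1ccc(NC(=O)c2cccc(/C=C3\CC(=O)N(c4ccccc4)C3=O)c2)cc1` in this assay gives > 100000 nM, again a limit rather than a number. Among the compounds with values here, the only step between measured neighbours, an at least 1.0-fold higher number from compound 1 to compound 3 (0.01 log units; that floor lies within the scatter), is capped by the limit of > 100000 nM in this assay, at which 2 of the 3 values shown sit, so its true size is unknown.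

Compound 4 `COc1ccc(NC(=O)c2cccc(/C=C3\CC(=O)N(c4ccc(C)cc4)C3=O)c2)cc1` differs from compound 3 by methoxy in place of chloro on an aromatic carbon. Within the data shown here, no measured step changes this group in this place, so there is no direct precedent for it. Compound 2 already carries the (4-methoxyphenyl)amino group and sits at the limit, and compound 3 with the (4-chlorophenyl)amino group sits there too; nothing in the measured values points to a number appearing below the limit once the methoxy group is introduced. Compound 4 is therefore expected to show no step beyond the scatter, a step that the limit leaves unreadable from compound 3 to compound 4, and to remain at the limit. The estimate for compound 4 in this assay is 150000 nM, with a range from 80000 nM to 400000 nM.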

Compound 4, half-maximal inhibitory concentration: 93000 nM
For compound 4 the middle estimate is 1.6-fold (0.21 log units) above the measured one; low and high end bracket the measured number.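

Within the data shown here, compound 4 shows that the 4-methoxyphenyl group at this place can give a readable number rather than a limit in this assay: the step is a 1.0-fold lower number from compound 1 to compound 4 (0.02 log units; within the scatter), the only new step with a number at both ends, so the 4-methoxyphenyl and 3-fluorophenyl groups cannot be told apart here. Methoxy in place of chloro on an aromatic carbon gives an at least 1.0-fold lower number from compound 3 to compound 4 (0.03 log units; that floor lies within the scatter), and methyl in place of hydrogen on an aromatic carbon gives an at least 1.0-fold lower number from compound 2 to compound 4 (0.03 log units; that floor lies within the scatter). Both of these steps start from a limit, so only their floors can be read and their true size remains unknown: the limit of > 100000 nM in this assay, at which 2 of the 4 values shown sit.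

What remains open is whether any change at this place can move the number beyond the scatter in this assay, since no step shown does so. It is also unknown whether an amine or a carboxylic acid in place of the methoxy group would give a clearly lower number than the methoxy group does in compound 4.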